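Urea series: chloro to trifluoromethyl on the terminal ring

The source may hold more compounds than are shown below. What is called first, only, known or untested is meant among the compounds shown, and "the series" means these compounds.

Measured compounds:
- compound 1 `COc1cc(-c2nn(-c3cccc(NC(=O)Nc4ccc(Cl)c(Cl)c4)c3)cc2-c2ccncc2)ccc1Cl` — in a functional assay on HOP-92 cells (Homo sapiens) for inhibition, read by sulforhodamine B assay, with a stated time of 48 h (on this read-out higher numbers stand for lower toxicity in this test and lower numbers for higher toxicity in this test), compound 1 gives only a limit, > 50000 nM
- compound 2 `O=C(Nc1cccc(-n2cc(-c3ccncc3)c(-c3ccc(Cl)c(O)c3)n2)c1)Nc1ccc(Cl)c(Cl)c1` — in this assay compound 2 gives only a limit, > 32500 nM

Both values are limits of this assay, not numbers. The step that the two limits leave unreadable from compound 1 to compound 2, hydrogen in place of methyl on an oxygen on an aromatic ring, therefore cannot be sized; the limit of > 32500 nM in this assay, at which 1 of the 2 values shown sits, and the limit of > 50000 nM in this assay, at which 1 of the 2 values shown sits, are all that bears on it. Compound 2 stands at one of the two limits shown, the other value being a limit as well.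

Compound 3 `O=C(Nc1cccc(-n2cc(-c3ccncc3)c(-c3ccc(Cl)c(O)c3)n2)c1)Nc1ccc(Cl)c(C(F)(F)F)c1` differs from compound 2 by trifluoromethyl in place of chloro on an aromatic carbon, ortho to a chloro group and meta to a large group. Among the measured compounds shown here, no measured step touches this position, and both measured compounds sit at limits. The expected step that the limit leaves unreadable from compound 2 to compound 3 is thus of no readable size. Compound 3 is estimated at 45000 nM, range 12000 nM to 150000 nM, most likely reported again as a limit.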

Compound 3, concentration lethal to 50% of the cells: 13500 nM
Compound 3: the middle estimate sits 3.3-fold (0.52 log units) above what was measured; measured number inside the range.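

Compound 3 is the first in the series to give a number rather than a limit in this assay, so the terminal ring is the first position shown to move this read-out. Trifluoromethyl in place of chloro on this aromatic carbon gives an at least 2.4-fold lower number from compound 2 to compound 3 (0.38 log units; beyond the scatter), which on this read-out means higher toxicity in this test. The true size of the step stays open, as it rests on a limit and not on a number at its starting end: the limit of > 32500 nM in this assay, at which 1 of the 3 values shown sits.

On these data alone, whether the same change has the same effect with the methyl on the oxygen, as in compound 1, remains open. Also open, as far as these compounds go, is how a nitrile, a methyl or an amine on the same aromatic carbon would read in this assay.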